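Ethoxy in Place of Chloro: Forecasting Compound 3

The source may report more compounds than this note shows. Statements on the series, on what has been measured and on what is new or still open speak of the compounds shown alone.

Going by the values given here, compound 2 `C=C(Br)C(=O)Nc1cccc(/C=C/C(=O)Nc2ccc(Cl)cc2)c1` gives 11000 nM in a functional assay on MCF7 cells (Homo sapiens) for inhibition, read by MTT assay, with a stated time of 72 h (on this read-out lower numbers stand for stronger inhibition and higher numbers for weaker inhibition), the higher of the two numbers measured so far. Compound 1 `C=C(Br)C(=O)Nc1cccc(/C=C/C(=O)Nc2cccc(F)c2)c1` gives 3300 nM in this assay, and the change from compound 1 to compound 2 was a 3.3-fold higher number from compound 1 to compound 2 (0.52 log units; beyond the scatter). Compound 3 `C=C(Br)C(=O)Nc1cccc(/C=C/C(=O)Nc2ccc(OCC)cc2)c1` differs from compound 2 by ethoxy in place of chloro on an aromatic carbon. Among the compounds with values here, the only measured step, from compound 1 to compound 2, altered both the halogen and where it sits on that ring, so it bears on the present change only by showing that a substituent on this ring can shift the number by a modest amount. Within the data shown here, no measured pair exchanges a halogen for an alkoxy group, so the direction is unknown. Compound 3 is therefore expected to land close to compound 2, with a step of a 1.4-fold lower number from compound 2 to compound 3 (0.14 log units; within the scatter) and wide uncertainty. The estimate for compound 3 is 8000 nM, within 2500 nM to 25000 nM.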

Compound 3, half-maximal inhibitory concentration: 5500 nM
The estimate for compound 3 lay 1.5-fold (0.16 log units) above the measured number; the range from low to high includes it.
By their numbers in this assay, from the lowest: compounds 1, 3 and 2 (each within the scatter of the next, the first and the last beyond it).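

In this assay, ethoxy in place of chloro on this aromatic carbon, para to a large group, gave a 2.0-fold lower number from compound 2 to compound 3 (0.30 log units; within the scatter). Going by these compounds alone, this is the first measured step in which one group replaces another at the same place on this ring, as the step from compound 1 to compound 2 also moved the halogen. It shows that this place can carry ethoxy, with its 3 heavy atoms and 1 hydrogen-bond acceptor, instead of the single chlorine atom without a change beyond the scatter, and no evidence accounts for this result.

On these data alone, whether an amine, a carboxylic acid or a longer alkoxy chain on this carbon would also stay within the scatter of compound 2 remains open. Also open, as far as these compounds go, is how ethoxy would read on the ring carbon that carries fluoro in compound 1.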